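This account rests on a few compounds, and the source may have more. Where it says the series, first, only, none or still open, it means among the compounds named here.

In a functional assay on MCF7 cells (Homo sapiens) for cytotoxicity, read by CellTiter-Glo, with a stated time of 5 days (a lower number here means a stronger inhibitor, a higher number a weaker inhibitor), compound 1 `CC/C(=C(/c1ccc(/C=C/C(=O)O)cc1)c1ccc2[nH]c(=O)oc2c1)c1ccccc1` gives 56 nM and compound 2 `CC/C(=C(/c1ccc(/C=C/C(=O)O)cc1)c1ccc2[nH]ncc2c1)c1ccccc1` gives 6 nM while compound 3 `CC/C(=C(\c1ccc2[nH]ncc2c1)c1ccc(/C=C/C(=O)O)cc1OC)c1ccccc1` gives 12 nM in the same test. The series spans a 9.3-fold lower number from compound 1 to compound 2 (0.97 log units; beyond the scatter) at its widest, and compound 2 sits at the low end of that span, level within the scatter with compound 3.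

Compound 4 `CC/C(=C(/c1ccc(/C=C/C(=O)O)cc1)c1ccc2[nH]ncc2c1)c1cccc(Cl)c1` departs from compound 2 in one place, where phenyl becomes 3-chlorophenyl. This is chloro in place of hydrogen on an aromatic carbon, meta to a large group (chloro in place of hydrogen on an aromatic carbon).

Within the data shown here, no measured pair alters that phenyl ring, so the evidence is only indirect. The nearest case is methoxy in place of hydrogen on an aromatic carbon in another part of the molecule, which gave a 2.0-fold higher number from compound 2 to compound 3 (0.30 log units; within the scatter) and so no clear shift. The wider step exchanged a whole ring group and says little about a single chloro.

No step beyond the scatter is therefore expected in this assay, and the estimated change is a 1.2-fold lower number from compound 2 to compound 4 (0.08 log units; within the scatter) in size. For compound 4 the expected value is 5 nM with an estimated range from 2 nM to 14 nM.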

Compound 4, half-maximal inhibitory concentration: 12 nM
Compound 4: middle estimate off by 2.4-fold (0.38 log units), on the low side; the measured number falls inside the stated range.
By their numbers in this assay, from the lowest: compounds 2, 3 and 4 (each within the scatter of the next); then compound 1.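

Among these compounds, the phenyl ring had stayed unchanged in the earlier compounds, and the first reading on it in this assay comes from chloro in place of hydrogen on an aromatic carbon, meta to a large group, with a 2.0-fold higher number from compound 2 to compound 4 (0.30 log units; within the scatter). This single chloro on the ring therefore gives no shift that can be told from the scatter, so this place accepts the added atom without a measurable penalty or gain in this test. It resembles the methoxy change on the other ring, a 2.0-fold higher number from compound 2 to compound 3 (0.30 log units; within the scatter), and neither single addition gives a step beyond the scatter, unlike the ring exchange, a 9.3-fold lower number from compound 1 to compound 2 (0.97 log units; beyond the scatter). No measurement among the data offers any explanation for this reading.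

On these data alone, whether fluoro, methyl, trifluoromethyl or an amine at this same place would also stay within the scatter remains open, as does the outcome for chloro at another place on this ring. The compounds shown also do not tell whether the chloro would read the same when combined with the methoxy of compound 3 or with the ring group of compound 1.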